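From heptyloxy to isopropoxy on the shared core

This account rests on a few compounds, and the source may have more. Where it says the series, first, only, none or still open, it means among the compounds named here.

Of the compounds shown here, three sharing one core have been tested in a functional assay on LNCaP cells (Homo sapiens) for antiproliferative activity, read by WST assay, with a stated time of 3 days; on this read-out lower numbers stand for stronger inhibition and higher numbers for weaker inhibition. There compound 1 (`CCOc1c(-c2cc(OC)c(OC)c(OC)c2)oc2ccccc2c1=O`) gives 5400 nM. Compound 2 (`CCCOc1c(-c2cc(OC)c(OC)c(OC)c2)oc2ccccc2c1=O`) has a propyl chain in place of the ethyl chain of compound 1. Compound 2 gives 5700 nM. The step between them, a 1.1-fold higher number from compound 1 to compound 2 (0.02 log units; within the scatter), shows no change in potency.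

Compound 3 (`CCCCCCCOc1c(-c2cc(OC)c(OC)c(OC)c2)oc2ccccc2c1=O`), which carries a heptyl chain, gives > 50000 nM, and this is a limit of the assay and not a number.

Compound 4 (`COc1cc(-c2oc3ccccc3c(=O)c2OC(C)C)cc(OC)c1OC`) has not yet been measured. It has isopropyl in place of heptyl on an oxygen on an aromatic ring.

Among the measured compounds shown here, two measured steps bear on this change when read in reverse: an at least 9.2-fold higher number from compound 1 to compound 3 (0.96 log units; beyond the scatter) and an at least 8.7-fold higher number from compound 2 to compound 3 (0.94 log units; beyond the scatter), both beyond the scatter. For the measured compounds named here, no compound with an isopropyl group has been measured, so the closest guides are compound 1 and compound 2. A step of similar size towards a lower number in this assay is therefore expected, with the caveat that compound 3 supplies only a limit as its starting point.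

The estimated step is an at least 9.0-fold lower number from compound 3 to compound 4 (0.95 log units; beyond the scatter).

Compound 4 is expected to give about 5500 nM.

The estimated range for compound 4 runs from 2200 nM to 14000 nM.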

Compound 4, half-maximal inhibitory concentration: 8800 nM
For compound 4 the middle estimate is 1.6-fold (0.20 log units) below the measured one, within the range that was stated.
By their numbers in this assay, from the lowest: compounds 1, 2 and 4 (each within the scatter of the next). At a limit, above all of these: compound 3.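

In this assay, the branched isopropyl group on the oxygen reads the same as the straight ethyl and propyl chains: a 1.6-fold higher number from compound 1 to compound 4 (0.21 log units; within the scatter) and a 1.5-fold higher number from compound 2 to compound 4 (0.19 log units; within the scatter) both stay within the scatter, so among these short groups branching at this place makes no visible difference. The other step, an at least 5.6-fold lower number from compound 3 to compound 4 (0.75 log units; beyond the scatter), lies beyond the scatter, which ties the poor result of compound 3 to the heptyl chain specifically, and not to just any group larger than ethyl on this oxygen. Compound 3 stands at a limit of the assay and not at a number, so the full size of that step stays unknown: the limit of > 50000 nM in this assay, at which 1 of the 4 values shown sits.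

The compounds shown leave open where between propyl and heptyl the number begins to climb, as a butyl or pentyl chain could tell, and whether a cyclopentyl ring on the oxygen would read like isopropyl. They also leave open whether an amine or a carboxylic acid at the end of a longer chain would keep the result of compound 3 or bring it back to that of compound 4.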